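The source may report more compounds than this note shows. Statements on the series, on what has been measured and on what is new or still open speak of the compounds shown alone.

Compound 1 `CC(C)[C@H]1COC(=O)N1c1ccnc(N[C@@H](C)c2ccc(-c3ccnc(C(F)(F)F)c3)cn2)n1`: 101 mL.min-1.g-1
Compound 2 `Cc1cc(-c2cnc([C@H](C)Nc3nccc(N4C(=O)OC[C@@H]4C(C)C)n3)cn2)ccc1F`: 641 mL.min-1.g-1
Compound 3 `Cc1cc([C@H](C)Nc2nccc(N3C(=O)OC[C@@H]3C)n2)ncc1-c1ccnc(C(F)(F)F)c1`: 36 mL.min-1.g-1

These three values come from an ADME assay on microsomes from liver (Rattus norvegicus) for metabolic stability, read by LC-MS, using NADPH, with a stated time of 30 min, tested at 1 uM; on this read-out lower numbers stand for slow clearance and higher numbers for fast clearance. Compound 3 stands lowest of the three at 36 mL.min-1.g-1, clear of the scatter from both others. The nearest neighbour is compound 1 at 101 mL.min-1.g-1, and the furthest away is compound 2 at 641 mL.min-1.g-1.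

The next compound to be tested is compound 4 `Cc1cc([C@H](C)Nc2nccc(N3C(=O)OC[C@@H]3C(C)C)n2)ncc1-c1ccnc(C(F)(F)F)c1`. It departs from compound 3 in a single place: isopropyl in place of methyl on a saturated ring carbon. Isopropyl stands in place of methyl on a saturated ring carbon, turning the 4-methyl-2-oxo-1,3-oxazolidin-3-yl group into 4-isopropyl-2-oxo-1,3-oxazolidin-3-yl.

Going by the values given here, no measured pair isolates this change, since the three measured compounds differ from one another in more than one place. Among the compounds with values here, the only guide is indirect. Compound 1 carries the same isopropyl group and gives 101 mL.min-1.g-1, and compound 2 also carries it and gives 641 mL.min-1.g-1. Both numbers exceed that of compound 3, although both compounds also differ from it elsewhere. The nearer value, that of compound 1, is taken as the better guide.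

The expected change, a 3.1-fold higher number from compound 3 to compound 4 (0.49 log units; beyond the scatter), is upward, towards faster clearance, and is expected to lie beyond the scatter. For compound 4 the estimated value is 110 mL.min-1.g-1, with an expected range from 50 mL.min-1.g-1 to 260 mL.min-1.g-1.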

Compound 4, intrinsic clearance in microsomes: 125 mL.min-1.g-1
For compound 4 the middle estimate is 1.1-fold (0.06 log units) below the measured one; measured number inside the range.
By their numbers in this assay, from the lowest: compound 3; then compounds 1 and 4 (each within the scatter of the next); then compound 2.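

In this assay the exchange of methyl for isopropyl on a saturated ring carbon, next to the ring nitrogen, can now be read on its own: it gives a 3.5-fold higher number from compound 3 to compound 4 (0.54 log units; beyond the scatter) and so moves the number towards faster clearance on an otherwise unchanged compound. The methyl in place of hydrogen on an aromatic carbon gives a 1.2-fold higher number from compound 1 to compound 4 (0.09 log units; within the scatter) and thus has no readable effect with isopropyl on the ring, so this one pair offers no sign that the aromatic methyl alters clearance in this setting. No separate measurement is at hand that would explain either step.

The compounds shown hold only methyl and isopropyl at the ring carbon, so it remains open whether hydrogen, ethyl or cyclopropyl there would fall between these two numbers or outside them. Going by these compounds, the step from methyl to isopropyl has also been read on a single background, and its size with the fluorinated methylphenyl group of compound 2 in place of the trifluoromethyl-bearing pyridine remains unknown.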